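Working notes: trifluoromethoxy in place of trifluoromethyl

The source may report more compounds than this note shows. Statements on the series, on what has been measured and on what is new or still open speak of the compounds shown alone.

Of the compounds shown here, two have been measured so far in a functional assay on VCaP cells (Homo sapiens) for antiproliferative activity, read by propidium iodide staining, with a stated time of 96 h; on this read-out lower numbers stand for stronger inhibition and higher numbers for weaker inhibition. Compound 1 (`CC(O)(COc1ccc(C#N)cc1)C(=O)Nc1ccc(S(F)(F)(F)(F)F)cc1`) gives 100000 nM. Compound 2 (`CC(O)(CS(=O)(=O)c1cccc(C(F)(F)F)c1)C(=O)Nc1ccc(S(F)(F)(F)(F)F)cc1`) gives 32000 nM, the lower of the two numbers, and the gap between them lies beyond the scatter. Compound 3 (`CC(O)(CS(=O)(=O)c1cccc(OC(F)(F)F)c1)C(=O)Nc1ccc(S(F)(F)(F)(F)F)cc1`) has not yet been measured. It carries trifluoromethoxy in place of trifluoromethyl on an aromatic carbon, meta to a large group: trifluoromethoxy in place of trifluoromethyl on an aromatic carbon. For the measured compounds named here, compounds 1 and 2 differ in more than one place, so no measured pair shows what a single change does here. As far as these compounds go, with so little to go on, no shift beyond the scatter is expected in this assay, and the direction stays open. The expected change is a 1.1-fold lower number from compound 2 to compound 3 (0.03 log units; within the scatter), an estimate within the scatter. For compound 3 the estimated value is 30000 nM, with an expected range from 12000 nM to 75000 nM.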

Compound 3, half-maximal inhibitory concentration: 23700 nM
Beside the measured number, compound 3's estimate is 1.3-fold (0.10 log units) above it; measured number inside the range.
By their numbers in this assay, from the lowest: compounds 3 and 2 (each within the scatter of the next); then compound 1.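

In this assay, for the compounds shown here, the change from 3-(trifluoromethyl)phenyl to 3-(trifluoromethoxy)phenyl gives a 1.4-fold lower number from compound 2 to compound 3 (0.13 log units; within the scatter) and is the first single-change step. On this aromatic carbon, meta to a large group, trifluoromethoxy in place of trifluoromethyl therefore does not separate compound 2 from compound 3 on this read-out, and both stay in the same range of numbers. No measurement of any property of these groups accompanies the result, so the step carries no explanation.

The compounds shown leave open what an amine or a carboxylic acid on this same aromatic carbon would do in this assay. As far as these compounds go, it also remains open whether trifluoromethoxy in place of trifluoromethyl gives a similar step on the core of compound 1, which differs from compound 2 in more than one place.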